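A few compounds are considered here, and "the series" means these few. Any claim that something is new, unique, unknown or untested is made for them only; others in the source may bear on it.

In an assay on isolated protein for inhibition of Aromatase (Homo sapiens), read by fluorescence and colorimetric assay, with a stated time of 30 min (on this read-out higher numbers stand for weaker inhibition and lower numbers for stronger inhibition), compound 1 `CCCCCCCc1cn(C(c2ccccc2)c2ccccc2)nn1` gives 19400 nM. Compound 2 `c1ccc(C(c2ccccc2)n2cc(C3CCCCC3)nn2)cc1` differs from compound 1 in one place, (cyclohexyl in place of heptyl on an aromatic carbon), and in this assay compound 2 gives 13700 nM; the step is a 1.4-fold lower number from compound 1 to compound 2 (0.15 log units; within the scatter). Compound 3 `CCCCCCCc1cn(Cc2ccc(C#N)cc2)nn1` rests on another core, and how that core differs from the core of compound 1 is not broken down here. In this assay compound 3 gives 3070 nM, the lowest of the three numbers. Compound 4 `N#Cc1ccc(Cn2cc(C3CCCCC3)nn2)cc1` has not yet been measured. It carries the same kind of change relative to compound 3: cyclohexyl in place of heptyl on an aromatic carbon. The two places are not described word for word alike: in compound 1 the ring atom two ring bonds away bears a large group, in compound 3 it bears a group of 9 heavy atoms. The earlier change moved the number only within the scatter. The step expected here is a 1.2-fold lower number from compound 3 to compound 4 (0.09 log units; within the scatter). That expectation rests on a 1.4-fold lower number from compound 1 to compound 2 (0.15 log units; within the scatter) and on compound 3 at 3070 nM. Compound 4 is therefore estimated at 2500 nM, with a range expected from 1200 nM to 5500 nM.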

Compound 4, half-maximal inhibitory concentration: 10700 nM
Compound 4: the middle estimate sits 4.3-fold (0.63 log units) below what was measured, outside the stated range (above it).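

In this assay, the swap of heptyl for cyclohexyl does not carry over unchanged from one core to the other: the same change on two cores in this assay, a 1.4-fold lower number (0.15 log units; within the scatter) from compound 1 to compound 2 and a 3.5-fold higher number (0.54 log units; beyond the scatter) from compound 3 to compound 4, 4.9-fold (0.69 log units) apart, beyond the scatter of two such steps. On the core of compound 3, the change gives a 3.5-fold higher number from compound 3 to compound 4 (0.54 log units; beyond the scatter), which means weaker inhibition, whereas on the core of compound 1 it left the number within the scatter. This shows that a step seen on one core cannot simply be added to another in this series, but with one pair per core it does not show why the cores respond differently or whether other swaps at this place would split in the same way.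

The compounds shown compare only heptyl and cyclohexyl at this place, so it remains open how a shorter chain such as butyl, a phenyl ring or an amine would behave on each core. No compound shown stands between the two cores, and which feature of them separates the two steps also remains open.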